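This account rests on a few compounds, and the source may have more. Where it says the series, first, only, none or still open, it means among the compounds named here.

Measured so far, in a functional assay on NCI-H460 cells (Homo sapiens) for cytotoxicity, read by MTT assay, with a stated time of 72 h; on this read-out lower numbers stand for stronger inhibition and higher numbers for weaker inhibition: compound 1 `CN(C)CCn1cnnc1-c1cc(Oc2ccc(NC(=O)N/N=C/c3c[nH]c4ccccc34)cc2F)ccn1` gives 1630 nM; compound 2 `CN(C)CCn1cnnc1-c1cc(Oc2ccc(NC(=O)N/N=C/c3ccc(O)c(Br)c3)cc2F)ccn1` gives 430 nM; compound 3 `COc1cc(/C=N/NC(=O)Nc2ccc(Oc3ccnc(-c4nncn4CCN(C)C)c3)c(F)c2)cc(OC)c1OC` gives 2770 nM.

Among these three, compound 2 shows the lowest number, and both of its steps to the others lie beyond the scatter, so it counts as the most potent of the set. The three compounds share one core and differ only in the aryl group on a carbon with a double bond to nitrogen. Compound 4 `CN(C)CCn1cnnc1-c1cc(Oc2ccc(NC(=O)N/N=C/c3cccc(Cl)c3Cl)cc2F)ccn1` keeps that core and changes the same position: 2,3-dichlorophenyl in place of 3-bromo-4-hydroxyphenyl on a carbon with a double bond to nitrogen.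

The steps seen at this position were a 3.8-fold lower number from compound 1 to compound 2 (0.58 log units; beyond the scatter) and a 6.4-fold higher number from compound 2 to compound 3 (0.81 log units; beyond the scatter), with a 1.7-fold higher number from compound 1 to compound 3 (0.23 log units; within the scatter) between the two other groups. Leaving the group of compound 2 in either direction so far gave a higher number. The dichlorophenyl group brings no donor or acceptor, as counted above, so a modest rise is expected rather than a further fall: compound 4 is estimated to show a 2.1-fold higher number from compound 2 to compound 4 (0.32 log units; beyond the scatter), giving an expected 900 nM with a likely range from 350 nM to 2500 nM.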

Compound 4, half-maximal inhibitory concentration: 72 nM
Estimate against measurement, compound 4: 13-fold (1.10 log units) above; measured number outside the range, below it.
By their numbers in this assay, from the lowest: compound 4; then compound 2; then compounds 1 and 3 (each within the scatter of the next).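

This position can reach well below the earlier best, with a 6.0-fold lower number from compound 2 to compound 4 (0.78 log units; beyond the scatter), and the 2,3-dichlorophenyl group also stands clear of the other two groups, with a 23-fold lower number from compound 1 to compound 4 (1.35 log units; beyond the scatter) and a 38-fold lower number from compound 3 to compound 4 (1.59 log units; beyond the scatter), making compound 4 the most potent of the four. A low number here therefore needs no hydrogen-bond donor or acceptor on this aryl group, since the 2,3-dichlorophenyl group carries neither, whereas the 3-bromo-4-hydroxyphenyl group of compound 2 carries one of each. Nothing measured on these compounds explains why this change lowers the number.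

This single change swaps the hydroxy and bromo groups for two chlorines, so the compounds shown cannot say which part of it matters. On these data alone, whether 2,3-difluorophenyl, 2,3-dimethylphenyl or unsubstituted phenyl would give a similarly low number stays open.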